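From 1-carboxyethyl to 1-carboxy-1-methylethyl: working notes

This account rests on a few compounds, and the source may have more. Where it says the series, first, only, none or still open, it means among the compounds named here.

Values measured in a physicochemical assay for lipophilicity, at pH 7.4; on this read-out higher numbers stand for higher lipophilicity and lower numbers for lower lipophilicity:
- compound 1 `CCn1nc(CC(=O)Nc2ccc(OC(F)(F)F)c(Cl)c2)c2ccccc2c1=O`: 5.42
- compound 2 `C[C@@H](C(=O)O)c1nn(Cc2cn3cc(OCC4CC4)c(Cl)cc3n2)c2ccccc2c1=O`: 2.41
- compound 3 `O=C(O)Cn1nc(Cn2cc3cc(OCC4CC4)c(Cl)cc3n2)c2ccccc2c1=O`: 2.79

Compound 2 stands lowest of the three numbers at 2.41. The nearest neighbour is compound 3 at 2.79, and the furthest is compound 1 at 5.42. Both gaps lie beyond the usual scatter. These compounds differ in more than one place, so neither gap isolates a single structural change.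

The next compound to be measured is compound 4 `CC(C)(C(=O)O)c1nn(Cc2cn3cc(OCC4CC4)c(Cl)cc3n2)c2ccccc2c1=O`. It carries 1-carboxy-1-methylethyl in place of 1-carboxyethyl on an aromatic carbon, next to the ring nitrogen (1-carboxy-1-methylethyl in place of 1-carboxyethyl on an aromatic carbon). Among the compounds with values here, the series holds no measured step of this kind, so the expectation rests on this structural change and on the starting value, with compound 2 at 2.41. A small upward step is expected in this assay, far smaller than the gap separating compound 2 from compound 1. The expected step is a number 0.34 log units higher from compound 2 to compound 4 (beyond the scatter). For compound 4 the estimated value is 2.75, with an expected range from 2.35 to 3.15.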

Compound 4, distribution coefficient: 2.95
The estimate for compound 4 lay 0.20 log units below the measured number; measured number inside the range.
By their numbers in this assay, from the lowest: compound 2; then compounds 3 and 4 (each within the scatter of the next); then compound 1.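

Position notes: on an aromatic carbon of the six-membered aromatic ring with 2 nitrogen, next to the ring nitrogen, 1-carboxy-1-methylethyl in place of 1-carboxyethyl gives in this assay a number 0.54 log units higher from compound 2 to compound 4 (beyond the scatter), the only step in the series that isolates a single change. The earlier gaps all involved compounds differing in more than one place, whereas here the rest of the molecule stays fixed: the group grows from 5 heavy atoms to 6, keeps its hydrogen-bond donor and acceptor counts, and loses the defined stereocentre. No measurement bearing on the origin of this step is available.

This single step cannot separate the contribution of the added carbon from that of losing the stereocentre, and the opposite stereoisomer of 1-carboxyethyl would bear directly on that question. Going by these compounds, it also remains open how this assay would respond at this position to a longer chain such as 2-carboxyethyl, to a cyclopropane ring carrying the carboxylic acid, or to a primary amide in place of the carboxylic acid.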